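The compounds below may be only part of what the source reports. "The series", "measured", "known", "first", "only" and "open" are said of these compounds alone.

Measured so far:
compound 1, `CSc1cn2c(n1)OC(C)(COc1ccc(OC(F)(F)F)cc1)C2`: 38000 nM
compound 2, `CC1(COc2ccc(OC(F)(F)F)cc2)Cn2cc(S(C)(=O)=O)nc2O1`: > 64000 nM, a limit of the assay
compound 3, `CSc1cnc2n1CC(C)(COc1ccc(OC(F)(F)F)cc1)O2`: 25000 nM

In an ADME assay on MRC5 cells (Homo sapiens) for cytotoxicity, read by fluorescence, with a stated time of 72 h (a higher number here means a weaker inhibitor, a lower number a stronger inhibitor), compound 1 gives 38000 nM and compound 3 gives 25000 nM; the two are built from the same atoms joined differently, and the difference between the two cores is not broken down here. Compound 2 gives > 64000 nM, which is a limit of the assay (the limit of > 64000 nM in this assay, at which 1 of the 3 values shown sits). The change from compound 1 to compound 2 is methylsulfonyl in place of methylsulfanyl on an aromatic carbon. It made an at least 1.6-fold higher number from compound 1 to compound 2 (0.22 log units; that floor lies within the scatter).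

Compound 4, `CC1(COc2ccc(OC(F)(F)F)cc2)Cn2c(S(C)(=O)=O)cnc2O1`, is not yet measured in this assay. It carries the same kind of change, (methylsulfonyl in place of methylsulfanyl on an aromatic carbon), the changed carbon here standing next to the ring atom that bears a fused ring rather than two ring bonds from two ring atoms that each bear a fused ring. The step is expected to be a 2.0-fold higher number from compound 3 to compound 4 (0.30 log units; within the scatter), resting on an at least 1.6-fold higher number from compound 1 to compound 2 (0.22 log units; that floor lies within the scatter). Compound 4 is therefore expected to give about 50000 nM, between 20000 nM and 150000 nM, possibly reported only as a limit.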

Compound 4, half-maximal inhibitory concentration: > 64000 nM
Compound 4 gave a limit, no number; the forecaster's own chance of this, stated with the estimate: 45%; middle value at least 1.2-fold (0.10 log units) away from the limit.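

Compound 4 gives > 64000 nM in this assay, which is a limit of the assay and not a number. Methylsulfonyl in place of methylsulfanyl gives an at least 2.5-fold higher number from compound 3 to compound 4 (0.40 log units; beyond the scatter), so on this second core the change clearly raises the number, in the direction the earlier step only hinted at. How large the change is on each core cannot be told, and so neither can whether it carries over at the same size: the same change on two cores in this assay, an at least 1.6-fold higher number (0.22 log units; that floor lies within the scatter) from compound 1 to compound 2 and an at least 2.5-fold higher number (0.40 log units; beyond the scatter) from compound 3 to compound 4; the limit leaves it open whether they differ

On these data alone, the true values of both methylsulfonyl compounds remain unknown, as they sit at the end of the measurable range: the limit of > 64000 nM in this assay, at which 2 of the 4 values shown sit. Also open is how another group on the same aromatic carbon, such as an amine or a carboxylic acid, would read in this assay.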